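The source may hold more compounds than are shown below. What is called first, only, known or untested is meant among the compounds shown, and "the series" means these compounds.

Working notes on the series, an assay on isolated protein for inhibition of DNA topoisomerase 1 (Homo sapiens), with a stated time of 30 min, tested at 100 uM; on this read-out lower numbers stand for a weaker effect and higher numbers for a stronger effect at the one concentration tested.

The three measured compounds share one core and differ only in the group on the aromatic carbon opposite the ring nitrogen. Compound 1 `Oc1cccc(-c2cc(-c3cccs3)cc(-c3ccccc3O)n2)c1` gives 83.2%, and compound 2 `Oc1cccc(-c2cc(-c3ccco3)cc(-c3ccccc3O)n2)c1` gives 90.1%; the step of a number 6.9 percentage points higher from compound 1 to compound 2 (within the scatter) is within the scatter. Compound 3 `Oc1cccc(-c2cc(-c3ccoc3)cc(-c3ccccc3O)n2)c1` gives 29.5% and stands lowest of the three, with steps a number 53.7 percentage points lower from compound 1 to compound 3 (beyond the scatter) and a number 60.6 percentage points lower from compound 2 to compound 3 (beyond the scatter) both beyond the scatter and large.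

Compound 4 `Oc1cccc(-c2cc(-c3ccccn3)cc(-c3ccccc3O)n2)c1` is not yet measured. It differs from compound 3 as follows: pyridin-2-yl in place of furan-3-yl on an aromatic carbon. Within the data shown here, the steps that bear on this change are those into compound 3, which show that moving from a five-membered ring linked through the carbon next to its hetero atom to furan-3-yl costs a large amount of the read-out. Pyridin-2-yl is again linked through the carbon next to its hetero atom, but a six-membered ring is untested here, so the bearing is indirect. A rise beyond the scatter is expected, a number 28.5 percentage points higher from compound 3 to compound 4 (beyond the scatter), though smaller than a full return. For compound 4 the estimated value in this assay is 58%, with a range from 25% to 88%.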

Compound 4, a percentage reported as inhibition, at one concentration (the size of the read-out at that concentration, not a potency): 35.4%
Compound 4: the middle estimate sits 22.6 percentage points above what was measured; low and high end bracket the measured number.
By their numbers in this assay, from the lowest: compounds 3 and 4 (each within the scatter of the next); then compounds 1 and 2 (each within the scatter of the next).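

In this assay, pyridin-2-yl on the carbon opposite the ring nitrogen gives no separation from furan-3-yl, a number 5.9 percentage points higher from compound 3 to compound 4 (within the scatter). Against the two high compounds the same group loses much of the read-out, a number 54.7 percentage points lower from compound 2 to compound 4 (beyond the scatter) and a number 47.8 percentage points lower from compound 1 to compound 4 (beyond the scatter), so among these four groups the high numbers belong only to furan-2-yl and thiophen-2-yl, and ring size alone does not sort the series, as furan-3-yl, also a five-membered aromatic ring, goes against it. Nothing at hand gives a reason for these differences.

Still open, on these data alone, is how plain phenyl, pyridin-3-yl or a non-aromatic group such as an amine would read at this position. As far as these compounds go, whether these steps would hold at other concentrations also stays open, as each number comes from a single concentration.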